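Dropping the Nitro Group: An Expectation for Compound 3

The compounds below may be only part of what the source reports. "The series", "measured", "known", "first", "only" and "open" are said of these compounds alone.

The two measured compounds:
Compound 1 `Cc1nc2c3ccccc3ccc2c2nc3c(ccc4ccccc43)c(-c3nccnc3N)c12` gives 81.7 ug/mL in a functional assay, read by spectrophotometry, with a stated time of 30 min; a lower number here means a stronger inhibitor, a higher number a weaker inhibitor.
Compound 2 `Cc1nc2c3ccccc3ccc2c2nc3c(ccc4ccccc43)c(-c3cc([N+](=O)[O-])ccc3N)c12` gives 93.1 ug/mL in this assay.

On the numbers shown, compound 2 cannot be told apart from compound 1: a 1.1-fold higher number from compound 1 to compound 2 (0.06 log units; within the scatter). The step examined here leads from compound 2 to compound 3 `Cc1nc2c3ccccc3ccc2c2nc3c(ccc4ccccc43)c(-c3ccccc3N)c12`, a change of hydrogen in place of nitro on an aromatic carbon. Going by the values given here, no measured step removes a nitro group on its own. Among the compounds with values here, the single step that bears on it is a 1.1-fold higher number from compound 1 to compound 2 (0.06 log units; within the scatter), which exchanged the whole ring carrying the nitro group for a different ring and still left the number within the scatter. A smaller change on the same ring is therefore expected to move the number little, with no direction beyond the scatter. Compound 3 is estimated at 85 ug/mL, with a range of 40 ug/mL to 180 ug/mL. This estimate corresponds to an expected 1.1-fold lower number from compound 2 to compound 3 (0.04 log units; within the scatter).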

Compound 3, half-maximal inhibitory concentration: 95.4 ug/mL
Compound 3: middle estimate off by 1.1-fold (0.05 log units), on the low side; measured number inside the range.
By their numbers in this assay, from the lowest: compounds 1, 2 and 3 (each within the scatter of the next).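

Going by these compounds alone, this is the first step that takes the nitro group off on its own, para to an amino group, and in this assay it reads a 1.0-fold higher number from compound 2 to compound 3 (0.01 log units; within the scatter) so at this place on the ring the number shows no dependence on the nitro group. With the nitro group gone, the comparison of the two rings themselves reads a 1.2-fold higher number from compound 1 to compound 3 (0.07 log units; within the scatter) so 2-aminophenyl and 3-aminopyrazin-2-yl cannot be told apart here either. No measured evidence accounts for how alike these three compounds read.

Still open, as far as these compounds go, is whether a different group at this same place, such as a carboxylic acid or a longer chain ending in an amine, would also leave the number unmoved. From the compounds shown here alone, the amino group is present in all three compounds, so what happens to the number without it remains unknown.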